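Removing the benzyl group from compound 2

The source may hold more compounds than are shown below. What is called first, only, known or untested is meant among the compounds shown, and "the series" means these compounds.

In a functional assay on HCT-15 cells (Homo sapiens) for cytotoxicity, read by colorimetric assay and MTT assay (a lower number here means a stronger inhibitor, a higher number a weaker inhibitor), compound 1 `COc1cc(OC)c2cc(-c3ccccc3)c(O)nc2c1` gives 10000 nM. Compound 2 `COc1cc(OC)c2cc(-c3ccc(OCc4ccccc4)cc3)c(O)nc2c1` gives 10000 nM, level with compound 1 at the digits shown. Compound 3 `COc1cc(OC)c2cc(-c3ccc(O)cc3)c(O)nc2c1` differs from compound 2 by hydrogen in place of benzyl on an oxygen on an aromatic ring, which reads as benzyloxy to hydroxy. Going by the values given here, only one measured step bears on this, and it concerns the same benzyloxy group: no change at the digits printed from compound 1 to compound 2 (within the scatter). On that evidence, no step beyond the scatter is expected in this assay. The estimated step is a 1.1-fold lower number from compound 2 to compound 3 (0.05 log units; within the scatter). For compound 3 the expected value is 9000 nM, with an estimated range of 4000 nM to 13000 nM.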

Compound 3, half-maximal inhibitory concentration: 10000 nM
Estimate against measurement, compound 3: 1.1-fold (0.05 log units) below; the range from low to high includes it.
By their numbers in this assay, from the lowest: compounds 1, 2 and 3 (each within the scatter of the next).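

In this assay, taking off the benzyl group gives no change at the digits printed from compound 2 to compound 3 (within the scatter), and hydroxy in place of hydrogen on the aromatic carbon gives no change at the digits printed from compound 1 to compound 3 (within the scatter). Hydroxy thus joins benzyloxy as a second group at this place that reads the same as hydrogen, where the earlier compounds showed only benzyloxy. Nothing measured here offers an explanation for this flat result.

The compounds shown leave open whether an amine or a carboxylic acid at this place would move the number at all. They also leave open whether changes elsewhere on the shared core would do so.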